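Methoxy Additions on a Purine Benzylamine Series

A few compounds are considered here, and "the series" means these few. Any claim that something is new, unique, unknown or untested is made for them only; others in the source may bear on it.

Compound 1 `Oc1ccc(CNc2ncnc3c2ncn3C2CCCCO2)cc1`: > 100000 nM
Compound 2 `COc1cc(CNc2ncnc3c2ncn3C2CCCCO2)ccc1O`: > 100000 nM
Compound 3 `COc1ccc(CNc2ncnc3c2ncn3C2CCCCO2)cc1OC`: > 100000 nM

In an ADME assay on K562 cells (Homo sapiens) for cytotoxicity, with a stated time of 72 h (on this read-out lower numbers stand for stronger inhibition and higher numbers for weaker inhibition), compound 1 gives only a limit of the assay. Compound 2 likewise gives only a limit. Compound 3 also gives only a limit. The step that the two limits leave unreadable from compound 1 to compound 2 and the step that the two limits leave unreadable from compound 2 to compound 3 therefore cannot be read, since (the limit of > 100000 nM in this assay, at which 3 of the 3 values shown sit).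

From compound 1 to compound 2 the change is methoxy in place of hydrogen on an aromatic carbon. Compound 4, `COc1ccc(CNc2ncnc3c2ncn3C2CCCCO2)c(OC)c1OC`, differs from compound 3 by methoxy in place of hydrogen on an aromatic carbon. The two are the same kind of change, yet the surroundings differ: in the first the new group sits ortho to a hydroxy group (1 heavy atom) and meta to a large group, in the second ortho to a large group, ortho to a methoxy group (2 heavy atoms) and meta to a methoxy group (2 heavy atoms). The difference between the two cores is not broken down here.

Given that compound 3 sits at the limit > 100000 nM in this assay, the step from compound 3 to compound 4 is expected to be a number no higher from compound 3 to compound 4 (the limit leaves the size open). Compound 4 is thus estimated at 100000 nM, between 50000 nM and 300000 nM.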

Compound 4, half-maximal inhibitory concentration: > 37500 nM
Compound 4: no number, only a limit; the forecaster's own chance of this, stated with the estimate: 85%; the middle value is on the limit's open side.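

Compound 3 and compound 4 both give only limits in this assay, so the step between them cannot be read. The compounds shown leave open whether methoxy in place of hydrogen on an aromatic carbon changes this read-out at all.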